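The compounds below may be only part of what the source reports. "The series", "measured", "known", "first", "only" and "open" are said of these compounds alone.

In a physicochemical assay for acid dissociation, read by capillary electrophoresis, tested at 100 uM, compound 1 (`O=S(=O)(O)CCc1ccccc1`) gives < 2, which is a limit and not a number. Compound 1 therefore stands at the limit of < 2 in this assay, at which 1 of the 2 values shown sits. The other measured compound, compound 2 (`CC(=O)NOCCc1ccccc1`), gives 9.58, a measured number that lies well higher on the scale. Among the measured compounds shown here, no step in one place links these two compounds, so the series offers no measured size for the change considered here.

Compound 3 (`O=S(O)CCc1ccccc1`) has yet to be measured in this assay. Its difference from compound 1 is hydroxysulfinyl in place of sulfo on a saturated chain carbon, two bonds along the chain from an aromatic carbon.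

The expectation starts from compound 1 at < 2, again only a limit. A small move towards a higher number is expected, and its size stays uncertain. The estimated step is a number at least 0.30 log units higher from compound 1 to compound 3 (that floor lies within the scatter). For compound 3 the expected value is 2.3, with an estimated range from 1.8 to 2.9.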

Compound 3, acid dissociation constant: 2.1
The estimate for compound 3 lay 0.20 log units above the measured number; low and high end bracket the measured number.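

In this assay, hydroxysulfinyl in place of sulfo on a saturated chain carbon, two bonds along the chain from an aromatic carbon, gives a readable value at the low end of the scale: compound 3 stands at 2.1. The change can now be written as a step, which is a number at least 0.10 log units higher from compound 1 to compound 3 (that floor lies within the scatter). The true size of that step cannot be fixed, because compound 1 stands at a limit and not at a number: the limit of < 2 in this assay, at which 1 of the 3 values shown sits.

Among the compounds shown here, it remains open whether hydroxysulfinyl and sulfo truly differ by more than the scatter at this position, and no step in one place links compound 2 to either of the other two compounds. Also open, from the compounds shown here alone, is how a carboxylic acid on the same saturated chain carbon would read in this assay, and whether a longer chain between the aromatic carbon and the hydroxysulfinyl group would shift the value seen for compound 3 .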